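Swapping 4-methoxyphenyl for 3-fluorophenyl on the shared core

The source may report more compounds than this note shows. Statements on the series, on what has been measured and on what is new or still open speak of the compounds shown alone.

Compound 1 `COc1cc(-c2ncnn2-c2cccc(N)c2)cc(OC)c1OC`: > 10000 nM (a limit)
Compound 2 `COc1ccc(-c2ncnn2-c2cc(OC)c(OC)c(OC)c2)cc1`: 280 nM

Within the data shown here, in a functional assay on HeLa cells (Homo sapiens) for antiproliferative activity, read by MTT assay, with a stated time of 72 h (a higher number here means a weaker inhibitor, a lower number a stronger inhibitor), compound 2 gives 280 nM, the only actual number so far. Compound 3 `COc1cc(-n2ncnc2-c2cccc(F)c2)cc(OC)c1OC` differs from compound 2 at one place: 3-fluorophenyl in place of 4-methoxyphenyl on an aromatic carbon. Among the measured compounds shown here, no measured step tests this change. A moderate loss of activity in this assay, beyond the scatter, is nevertheless expected, though this rests on judgement alone. The expected change is a 5.4-fold higher number from compound 2 to compound 3 (0.73 log units; beyond the scatter). Compound 3 is estimated at 1500 nM, with an expected range of 300 nM to 8000 nM.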

Compound 3, half-maximal inhibitory concentration: > 10000 nM
Compound 3: only a limit was reported; the forecaster's own chance of this, stated with the estimate: 20%; at least 6.6-fold (0.82 log units) between middle value and limit.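

In this assay, placing 3-fluorophenyl in place of 4-methoxyphenyl on this aromatic carbon gives an at least 35-fold higher number from compound 2 to compound 3 (1.55 log units; beyond the scatter), the first measured test of this position, and it shows that the activity of compound 2 is not kept through this change. Compound 3 gives > 10000 nM, which is a limit and not a number, and the full size of the step stays unread: the limit of > 10000 nM in this assay, at which 2 of the 3 values shown sit.

Going by these compounds, whether the loss follows the departing methoxy or the entering fluorine stays open. So does the effect at this place of a phenyl carrying a hydroxyl or an ethoxy group.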